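A few compounds are considered here, and "the series" means these few. Any claim that something is new, unique, unknown or untested is made for them only; others in the source may bear on it.

Going by the values given here, in a functional assay on PC-3 cells (Homo sapiens) for inhibition (on this read-out higher numbers stand for weaker inhibition and lower numbers for stronger inhibition), compound 2 `CCn1c(=O)/c(=C2\Sc3ccc(OC)cc3N2C)s/c1=C\c1ccncc1Nc1ccccc1F` gives 100 nM, the lowest of the two numbers measured so far. Its nearest neighbour, compound 1 `CCn1c(=O)/c(=C2\Sc3ccc(OC)cc3N2C)s/c1=C\c1ccncc1Nc1ccccc1C`, gives 370 nM. Among the compounds with values here, the single measured step, a 3.7-fold lower number from compound 1 to compound 2 (0.57 log units; beyond the scatter), arises from fluoro in place of methyl on an aromatic carbon. Compound 3 `CCn1c(=O)/c(=C2\Sc3ccc(OC)cc3N2C)s/c1=C\c1ccncc1Nc1ccccc1Cl` differs from compound 2 by chloro in place of fluoro on an aromatic carbon. Within the data shown here, no measured step sets chloro against fluoro, so that one step is only an indirect guide, and little movement is expected. For compound 3 a step of a 1.5-fold higher number from compound 2 to compound 3 (0.18 log units; within the scatter) in this assay is expected, giving an estimated 150 nM within a range from 60 nM to 400 nM.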

Compound 3, half-maximal inhibitory concentration: 760 nM
Beside the measured number, compound 3's estimate is 5.1-fold (0.70 log units) below it; the whole stated range lies below it.
By their numbers in this assay, from the lowest: compound 2; then compound 1; then compound 3.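

On this aromatic carbon, exchanging one halogen for the other is far from neutral in this assay: a 7.6-fold higher number from compound 2 to compound 3 (0.88 log units; beyond the scatter) is the largest step among these compounds. Chloro also trails methyl here, with a 2.1-fold higher number from compound 1 to compound 3 (0.31 log units; beyond the scatter) as the step, so the order fluoro, methyl, chloro does not simply track the two halogens as a pair. Nothing available here accounts for this order. The compounds shown leave open how a methoxy group, a nitrile or a plain hydrogen at this place would compare with fluoro. They also leave open whether bromo would continue the fall seen with chloro.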